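Cyanoaziridine ureas: swapping nitro for fluoro on the aryl

The source may report more compounds than this note shows. Statements on the series, on what has been measured and on what is new or still open speak of the compounds shown alone.

Measured so far:
- compound 1, `N#CC1CN1C(=O)Nc1ccc(Cl)cc1Cl`: 33000 nM
- compound 2, `N#CC1CN1C(=O)Nc1ccc([N+](=O)[O-])cc1`: 2600 nM
- compound 3, `N#CC1CN1C(=O)NC1CCCCC1`: 16000 nM

All three share a cyanoaziridine urea; they differ only in the group attached to the urea nitrogen. In a functional assay on L1210 cells (Mus musculus) for inhibition, read by MTT assay (a higher number here means a weaker inhibitor, a lower number a stronger inhibitor), compound 2 gives 2600 nM, the lowest number of the three. Compound 3, with a cyclohexyl in place of the aryl, gives 16000 nM, and compound 1, carrying two chloro groups on its aryl, gives 33000 nM; both gaps to compound 2 lie beyond the scatter. The nitro-bearing aryl thus stands apart from the other two variants so far.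

Compound 4, `N#CC1CN1C(=O)Nc1ccc(F)cc1`, is not yet measured. Against compound 2 the change is fluoro in place of nitro on an aromatic carbon. Within the data shown here, no pair of measured compounds differs in one place, so the step cannot be read from any measured pair, and the comparison rests on where compound 2 stands against compounds 1 and 3. An upward step is expected, putting compound 4 between compound 2 and compound 3. The step expected is a 3.5-fold higher number from compound 2 to compound 4 (0.54 log units; beyond the scatter), in the direction of weaker inhibition. For compound 4 in this assay the estimate is 9000 nM, with a range from 3000 nM to 30000 nM.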

Compound 4, half-maximal inhibitory concentration: 5900 nM
The estimate for compound 4 lay 1.5-fold (0.18 log units) above the measured number, within the range that was stated.
By their numbers in this assay, from the lowest: compound 2; then compound 4; then compound 3; then compound 1.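

In this assay, among these compounds, the change at the aromatic carbon para to a group of 8 heavy atoms gives a 2.3-fold higher number from compound 2 to compound 4 (0.36 log units; beyond the scatter) as the first step that can be read between two compounds differing in one place. It shows that this position is sensitive to the group it carries, although the step is modest: 3 heavy atoms with 2 hydrogen-bond acceptors leave, a single fluorine with 0 hydrogen-bond acceptors enters, and inhibition weakens only to this limited extent. Nothing measured in this set bears on the reason for the step.

Only nitro and fluoro can be compared at this aromatic carbon, which leaves open whether the number follows the size of the group, its hydrogen-bond acceptors or something else, and an amine, a carboxylic acid or a methoxy group at the same carbon would help to separate these readings. Also open, as far as these compounds go, is whether the swap of nitro for fluoro would give a step of similar size if the rest of the aryl carried a further group.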